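Chloro substitution and whole-organism activity on Oryza sativa

The compounds below may be only part of what the source reports. "The series", "measured", "known", "first", "only" and "open" are said of these compounds alone.

Compound 1 `C[C@@H](NC(=O)Nc1ccccc1Cl)c1ccccc1`, compound 2 `C[C@@H](NC(=O)Nc1cccc(Cl)c1)c1ccccc1` and compound 3 `C[C@@H](NC(=O)Nc1ccc(Cl)cc1Cl)c1ccccc1` share one core; compound 4 `C[C@@H](NC(=O)Nc1ccc(Cl)c(Cl)c1)c1ccccc1` has not been measured. In an ADME assay on the whole organism with Oryza sativa as the target, tested at 0.1 uM (on this read-out higher numbers stand for a weaker effect at the one concentration tested and lower numbers for a stronger effect), compound 1 gives 101%, compound 2 gives 97% and compound 3 gives 101%, and the three numbers lie within the scatter of one another. The change chloro in place of hydrogen on an aromatic carbon gives no change at the digits printed from compound 1 to compound 3 (within the scatter). The difference between the cores of compound 1 and compound 2 is not broken down here. Compound 4 carries the same kind of change, (chloro in place of hydrogen on an aromatic carbon), but here the entering chloro sits ortho to a chloro group rather than meta to one. For compound 4 a step of a number 2 percentage points higher from compound 2 to compound 4 (within the scatter) is expected in this assay, resting on the unchanged read-out of no change at the digits printed from compound 1 to compound 3 (within the scatter). Compound 4 is therefore estimated at 99%, with a range from 90% to 108%.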

Compound 4, a percentage reported as activity, at one concentration (the size of the read-out at that concentration, not a potency): 98%
Estimate against measurement, compound 4: 1 percentage points above, and the stated range covers the measured number.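

In this assay, chloro in place of hydrogen on an aromatic carbon gives a number 1 percentage points higher from compound 2 to compound 4 (within the scatter), and this agrees with the earlier step on the other core: the same change on two cores in this assay, no change at the digits printed (within the scatter) from compound 1 to compound 3 and a number 1 percentage points higher (within the scatter) from compound 2 to compound 4, 1 percentage points apart, within the scatter of two such steps In these two cases, the change carries from one core to the other with no readable effect on this read-out, including where the entering chloro sits ortho to a chloro group. Both steps lie within the scatter, so this is agreement between two null results and does not show that the change would carry over on a core where it had a readable effect.

The compounds shown vary only in chloro groups on one aromatic ring of the shared core. As far as these compounds go, whether a nitrile, a methoxy group or an amine on that ring would move the read-out remains open.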